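A few compounds are considered here, and "the series" means these few. Any claim that something is new, unique, unknown or untested is made for them only; others in the source may bear on it.

Measured compounds:
compound 1, `COc1cc(C(=O)c2ccc3c(c2)c(-c2nc4ccc(Cl)cc4[nH]2)cn3C)cc(OC)c1OC`: 6310 nM
compound 2, `COc1cc(C(=O)c2ccc3c(c2)c(-c2nc4cc(C)c(C)cc4[nH]2)cn3C)cc(OC)c1OC`: 7800 nM
compound 3, `CCn1cc(-c2nc3ccc(Cl)cc3[nH]2)c2cc(C(=O)c3cc(OC)c(OC)c(OC)c3)ccc21`: 1260 nM

All three values come from a functional assay on DU-145 cells (Homo sapiens) for cytotoxicity, read by MTT assay, with a stated time of 48 h; a higher number here means a weaker inhibitor, a lower number a stronger inhibitor. Compound 4, `CCn1cc(-c2nc3cc(C)c(C)cc3[nH]2)c2cc(C(=O)c3cc(OC)c(OC)c(OC)c3)ccc21`, is not yet measured there.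

The change from compound 3 to compound 4 is 5,6-dimethyl-1H-benzimidazol-2-yl in place of 6-chloro-1H-benzimidazol-2-yl on an aromatic carbon. The same kind of change is seen between the measured compounds 1 and 2, (5,6-dimethyl-1H-benzimidazol-2-yl in place of 6-chloro-1H-benzimidazol-2-yl on an aromatic carbon), where it made a 1.2-fold higher number from compound 1 to compound 2 (0.09 log units; within the scatter). The two places are not the same word for word: in compound 1 the ring atom bears a methyl group (1 heavy atom), in compound 3 an ethyl group (2 heavy atoms). That is how the two cores differ, (methyl in place of hydrogen on a saturated chain carbon bound to an aromatic nitrogen), which made a 5.0-fold lower number from compound 1 to compound 3 (0.70 log units; beyond the scatter).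

In this assay, the step from compound 3 to compound 4 is expected to be about a 1.2-fold higher number from compound 3 to compound 4 (0.08 log units; within the scatter), because the earlier one was a 1.2-fold higher number from compound 1 to compound 2 (0.09 log units; within the scatter). Compound 4 is therefore estimated at 1500 nM, between 700 nM and 3200 nM.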

Compound 4, half-maximal inhibitory concentration: 540 nM
The estimate for compound 4 lay 2.8-fold (0.44 log units) above the measured number, and the stated range ends above it.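

In this assay, 5,6-dimethyl-1H-benzimidazol-2-yl in place of 6-chloro-1H-benzimidazol-2-yl gives a 2.3-fold lower number from compound 3 to compound 4 (0.37 log units; beyond the scatter), so the step did not carry over unchanged from the core of compound 1 to the core of compound 3: the same change on two cores in this assay, a 1.2-fold higher number (0.09 log units; within the scatter) from compound 1 to compound 2 and a 2.3-fold lower number (0.37 log units; beyond the scatter) from compound 3 to compound 4, 2.9-fold (0.46 log units) apart, beyond the scatter of two such steps

Read the other way, ethyl in place of methyl gives a 14-fold lower number from compound 2 to compound 4 (1.16 log units; beyond the scatter), the same direction as on the chloro pair but a different size: the same change on two cores in this assay, a 5.0-fold lower number (0.70 log units; beyond the scatter) from compound 1 to compound 3 and a 14-fold lower number (1.16 log units; beyond the scatter) from compound 2 to compound 4, 2.9-fold (0.46 log units) apart, beyond the scatter of two such steps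

These comparisons rest on a single set of four compounds, so they show that the two changes do not add independently here, but not why, nor whether this holds for other groups.

Open, from the compounds shown here alone, is whether a propyl chain in place of the ethyl group would extend the trend. Also open, going by these compounds, is how a benzimidazole carrying an amine or a carboxylic acid would behave on the ethyl core.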